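Thiophen-2-yl to thiophen-3-yl on the shared core

The compounds below may be only part of what the source reports. "The series", "measured", "known", "first", "only" and "open" are said of these compounds alone.

In a functional assay on HL-60 cells (Homo sapiens) for antiproliferative activity, read by XTT assay, with a stated time of 72 h (a higher number here means a weaker inhibitor, a lower number a stronger inhibitor), compound 1 (`CSc1ncnc2c1c(-c1ccsc1)cn2[C@@H]1O[C@H](CO)[C@@H](O)[C@H]1O`) gives 4590 nM. Compound 2 (`CNc1ncnc2c1c(-c1cccs1)cn2[C@@H]1O[C@H](CO)[C@@H](O)[C@H]1O`) gives only a limit of the assay, > 20000 nM. Compound 3 (`CNc1ncnc2c1c(-c1ccsc1)cn2[C@@H]1O[C@H](CO)[C@@H](O)[C@H]1O`) follows from compound 2 by one change on an aromatic carbon, thiophen-3-yl in place of thiophen-2-yl on an aromatic carbon. Within the data shown here, no measured step shows what this swap does in this assay, so the expectation is a modest gain in strength, with a fair chance of remaining at the limit. The estimated step is an at least 2.2-fold lower number from compound 2 to compound 3 (0.34 log units; beyond the scatter). For compound 3 the expected value is 9000 nM, within an estimated range of 2500 nM to 20000 nM.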

Compound 3, half-maximal inhibitory concentration: > 20000 nM
Compound 3: no number, only a limit; the forecaster's own chance of this, stated with the estimate: 35%; middle value at least 2.2-fold (0.34 log units) away from the limit.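

In this assay, the change from thiophen-2-yl to thiophen-3-yl cannot be read, because compound 2 and compound 3 both rest on a limit of the assay: the limit of > 20000 nM in this assay, at which 2 of the 3 values shown sit.

Among these compounds, with thiophen-3-yl kept in place, methylamino in place of methylsulfanyl on an aromatic carbon gives an at least 4.3-fold higher number from compound 1 to compound 3 (0.63 log units; beyond the scatter), the one readable step so far. Among the compounds shown here, the methylsulfanyl group thus marks the only compound with a number here.

Open, as far as these compounds go, are how a thiophen-2-yl partner of compound 1 would read and whether ethylsulfanyl or dimethylamino on that carbon would stay within reach of the assay.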